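This account rests on a few compounds, and the source may have more. Where it says the series, first, only, none or still open, it means among the compounds named here.

Measured compounds:
- compound 1, `CC(C)(C)C(=O)N1N=CCC1c1cocn1`: 3
- compound 2, `O=C(c1ccccc1)N1CCC(C(=O)N2N=CCC2c2ccccc2)CC1`: 4.4

In a physicochemical assay for lipophilicity, read by HPLC, measured as chromatographic lipophilicity, at pH 7.4 (on this read-out higher numbers stand for higher lipophilicity and lower numbers for lower lipophilicity), compound 1 gives 3, the lower of the two numbers, and compound 2 gives 4.4, a gap that lies beyond the usual scatter. These two compounds differ in more than one place, so their values show only where each stands.

Compound 3, `CC(C)(C)C(=O)N1N=CCC1C1CCCC1`, is not yet measured. It differs from compound 1 in one place: cyclopentyl in place of 1,3-oxazol-4-yl on a saturated ring carbon. A group with 2 hydrogen-bond acceptors leaves and a carbon-only ring enters. The step of a number 1.20 log units higher from compound 1 to compound 3 (beyond the scatter) is therefore expected to be upward and clearly beyond the scatter. Compound 3 is estimated at 4.2, within 3.6 to 4.8.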

Compound 3, distribution coefficient: 6.7
Compound 3: middle estimate off by 2.50 log units, on the low side; measured number above the stated range.
By their numbers in this assay, from the lowest: compound 1; then compound 2; then compound 3.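

In this assay cyclopentyl in place of 1,3-oxazol-4-yl on this saturated ring carbon gives a number 3.70 log units higher from compound 1 to compound 3 (beyond the scatter) while the count of heavy atoms stays the same. Going by these compounds alone, this is the first comparison here that isolates one place, and it shows that this position can carry a large step even when one five-membered ring simply replaces another. Nothing available gives a reason for the size of this step.

An amine, a carboxylic acid or a longer chain on this carbon remains an open case. As far as these compounds go, whether the same exchange would give a step of similar size on another core also remains open.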